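The source may report more compounds than this note shows. Statements on the series, on what has been measured and on what is new or still open speak of the compounds shown alone.

In an ADME assay on L1210/0 cells (Mus musculus) for cytotoxicity, with a stated time of 48 h (a lower number here means a stronger inhibitor, a higher number a weaker inhibitor), compound 1 `O=C(CI)NCc1cn([C@H]2C[C@H](O)[C@@H](CO)O2)c(=O)[nH]c1=O` gives 107000 nM. Compound 2 `COCC#Cc1cn([C@H]2C[C@H](O)[C@@H](CO)O2)c(=O)[nH]c1=O` is reported only as a limit, > 200000 nM. Compound 3 `O=c1[nH]c(=O)n([C@H]2C[C@H](O)[C@@H](CO)O2)cc1C#CCCO` is likewise reported only as a limit, > 200000 nM. That places it at the limit of > 200000 nM in this assay, at which 2 of the 3 values shown sit. The measured steps offer little guidance: an at least 1.8-fold higher number from compound 1 to compound 2 (0.27 log units; that floor lies within the scatter), an at least 1.8-fold higher number from compound 1 to compound 3 (0.27 log units; that floor lies within the scatter) and a step that the two limits leave unreadable from compound 2 to compound 3. Compound 4 `CCCc1cn([C@H]2C[C@H](O)[C@@H](CO)O2)c(=O)[nH]c1=O` differs from compound 3 by propyl in place of 4-hydroxybut-1-yn-1-yl on an aromatic carbon, with propyl in place of 4-hydroxybut-1-yn-1-yl on an aromatic carbon. For the measured compounds named here, no measured step covers this exchange, and the readable floors stay within the scatter, so no step beyond the scatter is expected. The estimated step is a number no higher from compound 3 to compound 4 (the limit leaves the size open). Compound 4 is expected at 200000 nM, within an estimated range from 80000 nM to 400000 nM.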

Compound 4, half-maximal inhibitory concentration: > 200000 nM
Compound 4 was reported as a limit; the forecaster's own chance of this, stated with the estimate: 60%; the middle value lies on the limit itself.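

In this assay, the propyl chain, with no triple bond and no hydrogen-bond donor, ends at the same limit as the two alkynyl chains, so this position shows no readable difference among the three groups: the limit of > 200000 nM in this assay, at which 3 of the 4 values shown sit.

The steps among compound 2, compound 3 and compound 4 cannot be read, since both ends of each are limits. For the compounds shown here, the only readable comparison is an at least 1.8-fold higher number from compound 1 to compound 4 (0.27 log units; that floor lies within the scatter).

From the compounds shown here alone, whether a shorter chain such as ethyl, or an amine or a carboxylic acid on a longer chain, would give a value clear of the limit stays open. So does whether the iodine of compound 1 matters to its measured value.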